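The source may report more compounds than this note shows. Statements on the series, on what has been measured and on what is new or still open speak of the compounds shown alone.

In a functional assay on A-375 cells (Homo sapiens) for antiproliferative activity, read by MTT assay, with a stated time of 72 h (a lower number here means a stronger inhibitor, a higher number a weaker inhibitor), compound 3 `COc1ccc(N2C(=O)COc3ccc(-c4cnc5ccccc5c4)cc32)cc1` gives > 40000 nM, which is a limit and not a number. That places compound 3 at the limit of > 40000 nM in this assay, at which 1 of the 3 values shown sits. Compound 4 `O=C1COc2ccc(-c3cnc4ccccc4c3)cc2N1c1ccccc1` differs from it by hydrogen in place of methoxy on an aromatic carbon, para to a large group (hydrogen in place of methoxy on an aromatic carbon), so that 4-methoxyphenyl becomes phenyl.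

Going by the values given here, only one measured step touches this methoxy group: an at least 1.6-fold higher number from compound 1 to compound 3 (0.22 log units; that floor lies within the scatter). It gives no exact size, and its floor lies within the scatter. Compound 1 `COc1cccc(N2C(=O)COc3ccc(-c4cnc5ccccc5c4)cc32)c1`, which carries 3-methoxyphenyl, gives a measurable 23600 nM. Compound 2 `COc1ncc(-c2ccc3c(c2)N(c2ccccc2)C(=O)CO3)cc1NS(=O)(=O)c1ccc(F)cc1` already carries phenyl on the ring nitrogen and gives 15200 nM, but it differs from compound 4 at another place as well, so it offers only a rough guide.

On these values, a modest move towards a lower number in this assay is expected, and it may not exceed the scatter. The expected change is an at least 1.4-fold lower number from compound 3 to compound 4 (0.17 log units; that floor lies within the scatter). Compound 4 is estimated at 27000 nM, with an expected range from 12000 nM to 60000 nM.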

Compound 4, half-maximal inhibitory concentration: > 40000 nM
Compound 4: only a limit was reported; the forecaster's own chance of this, stated with the estimate: 35%; at least 1.4-fold (0.17 log units) between middle value and limit.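

In this assay, the phenyl compound gives a second comparison with the 3-methoxyphenyl compound: an at least 1.6-fold higher number from compound 1 to compound 4 (0.22 log units; that floor lies within the scatter). Among the three compounds that differ only at this group, compound 1 alone gives a measurable value, while phenyl, like 4-methoxyphenyl, gives only a limit; the floors of both readable steps lie within the scatter, so this is no firm gain for 3-methoxyphenyl. The step between the 4-methoxyphenyl and phenyl compounds cannot be read, because both stand at the same limit: the limit of > 40000 nM in this assay, at which 2 of the 4 values shown sit.

On these data alone, how far the true values of compound 3 and compound 4 lie beyond that limit stays open, and with it whether either really differs from compound 1. Also open, as far as these compounds go, is how an amine or a carboxylic acid in place of the methoxy group would read here.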